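The compounds below may be only part of what the source reports. "The series", "measured", "known", "first", "only" and "open" are said of these compounds alone.

Compound 1 `Cc1cc(-c2ccccc2)cn2c(CSCCc3ccccc3)cnc12` gives 31 ug/mL in an ADME assay on HEL cells (Homo sapiens) for cytotoxicity, with a stated time of 3 days; a higher number here means that more compound is tolerated, a lower number that less compound is tolerated. Compound 2 `Cc1cc(-c2ccc(O)cc2)cn2c(CSCCc3ccccc3)cnc12` gives > 50 ug/mL in this assay, which is a limit of the assay and not a number.

Compound 2 thus stands at the limit of > 50 ug/mL in this assay, at which 1 of the 2 values shown sits, so only a floor is known for it. Compound 3 `COc1cccc(-c2cc(C)c3ncc(CSCCc4ccccc4)n3c2)c1` differs from it by 3-methoxyphenyl in place of 4-hydroxyphenyl on an aromatic carbon. For the measured compounds named here, the one measured step that bears on this, an at least 1.6-fold higher number from compound 1 to compound 2 (0.20 log units; that floor lies within the scatter), came with a hydroxy entering; here the hydroxy leaves again and a methoxy enters, so any movement back toward compound 1 is expected to stay within the scatter. Compound 3 is therefore estimated at 40 ug/mL, between 20 ug/mL and 80 ug/mL, an expected step of an at least 1.2-fold lower number from compound 2 to compound 3 (0.09 log units; that floor lies within the scatter).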

Compound 3, half-maximal cytotoxic concentration: 36 ug/mL
Compound 3: middle estimate off by 1.1-fold (0.05 log units), on the high side; measured number inside the range.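

With 3-methoxyphenyl on this aromatic carbon, the ring carries no hydrogen-bond donor, and this assay gives a 1.2-fold higher number from compound 1 to compound 3 (0.06 log units; within the scatter). Against the 4-hydroxyphenyl group the result is an at least 1.3-fold lower number from compound 2 to compound 3 (0.14 log units; that floor lies within the scatter), which is only a floor. Compound 2 stands at a limit of the assay and not a number: the limit of > 50 ug/mL in this assay, at which 1 of the 3 values shown sits.

The compounds shown leave open whether the group's place on the ring or the exchange of hydroxy for methoxy matters more here. They also leave open how an amine or a carboxylic acid on this phenyl ring would read in this assay.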